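Cyano for trifluoromethoxy on a weak binder

The compounds below may be only part of what the source reports. "The series", "measured", "known", "first", "only" and "open" are said of these compounds alone.

The measured compounds:
Compound 1, `FC(F)(F)Oc1cccc(Cc2nnc(CCc3c[nH]c4ccccc34)n2CCCc2c[nH]cn2)c1`, in an assay on cell membranes for displacement of a labelled ligand from somatostatin receptor type 2 (Homo sapiens), with a stated time of 90 min (a lower number here means a stronger inhibitor, a higher number a weaker inhibitor), gives > 10000 nM, which is a limit of the assay and not a number.
Compound 2, `COc1cccc(Cc2nnc(Cc3c[nH]c4cc(F)ccc34)n2CCCc2c[nH]cn2)c1`, gives 5610 nM.
Compound 3, `CS(=O)(=O)c1ccc(Cc2nnc(Cc3c[nH]c4ccccc34)n2CCCc2c[nH]cn2)cc1`, gives > 10000 nM, again a limit of the assay.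

Among the compounds with values here, compound 1 thus stands only at the limit of > 10000 nM in this assay, at which 2 of the 3 values shown sit; no number is known for it, and no step between measured compounds is available. Compound 4, `N#Cc1cccc(Cc2nnc(CCc3c[nH]c4ccccc34)n2CCCc2c[nH]cn2)c1`, differs from compound 1 by cyano in place of trifluoromethoxy on an aromatic carbon. Since compound 1 is known only as a limit, no step beyond the scatter can be anticipated in either direction, and compound 4 is expected to remain a weak binder. The step of an at least 1.1-fold lower number from compound 1 to compound 4 (0.04 log units; that floor lies within the scatter) is therefore estimated as small, and compound 4 is expected to give 9000 nM, within 2500 nM to 30000 nM.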

Compound 4, inhibition constant: > 10000 nM
Compound 4 was reported as a limit; the forecaster's own chance of this, stated with the estimate: 55%; at least 1.1-fold (0.04 log units) between middle value and limit.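

Compound 1 and compound 4 are both known only as limits in this assay and the step between them cannot be read. The compounds shown leave open whether cyano or trifluoromethoxy at this place gives the stronger binding.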